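The source may hold more compounds than are shown below. What is called first, only, known or untested is meant among the compounds shown, and "the series" means these compounds.

Compound 1 `CC(C)C[C@H](NC(=O)CCSc1cc(NS(=O)(=O)c2cccs2)c2ccccc2c1O)B(O)O` and compound 2 `CC(=O)Nc1ccc(S(=O)(=O)Nc2cc(SCCC(=O)N[C@@H](CC(C)C)B(O)O)c(O)c3ccccc23)cc1` differ only at one point: 4-acetamidophenyl in place of thiophen-2-yl on a sulfonyl sulfur. In a functional assay on MCF7 cells (Homo sapiens) for antiproliferative activity, read by sulforhodamine B assay, with a stated time of 72 h (a lower number here means a stronger inhibitor, a higher number a weaker inhibitor), compound 1 gives 6470 nM, while compound 2 gives 6620 nM, so the step of a 1.0-fold higher number from compound 1 to compound 2 (0.01 log units; within the scatter) is essentially flat. Compound 3 `CC(C)C[C@H](NC(=O)C(C)Sc1cc(NS(=O)(=O)c2cccs2)c2ccccc2c1O)B(O)O` has the same atoms as compound 1, joined differently; the difference between the two cores is not broken down here. In this assay compound 3 gives 14700 nM, the highest of the three numbers and beyond the scatter from both others. Compound 4 `CC(=O)Nc1ccc(S(=O)(=O)Nc2cc(SC(C)C(=O)N[C@@H](CC(C)C)B(O)O)c(O)c3ccccc23)cc1` stands to compound 3 as compound 2 stands to compound 1, through the same change, (4-acetamidophenyl in place of thiophen-2-yl on a sulfonyl sulfur), made at the same place. Because a 1.0-fold higher number from compound 1 to compound 2 (0.01 log units; within the scatter) was within the scatter, compound 4 is expected to show a similarly flat step, a 1.0-fold lower number from compound 3 to compound 4 (0.01 log units; within the scatter). Compound 4 is therefore estimated at about 14500 nM, likely between 7000 nM and 30000 nM.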

Compound 4, half-maximal inhibitory concentration: 8910 nM
Beside the measured number, compound 4's estimate is 1.6-fold (0.21 log units) above it; the range from low to high includes it.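

On the core of compound 3, 4-acetamidophenyl in place of thiophen-2-yl on the sulfonyl sulfur gives a 1.6-fold lower number from compound 3 to compound 4 (0.22 log units; within the scatter) in this assay, so the step stays within the scatter, as it did on the core of compound 1. Set side by side, the two steps do not differ beyond what two such steps can scatter: the same change on two cores in this assay, a 1.0-fold higher number (0.01 log units; within the scatter) from compound 1 to compound 2 and a 1.6-fold lower number (0.22 log units; within the scatter) from compound 3 to compound 4, 1.7-fold (0.23 log units) apart, within the scatter of two such steps This shows the change carrying across these two cores without a detectable difference, but two pairs in one assay do not show that it would carry to any other core.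

The compounds shown leave open whether a different group on the sulfonyl sulfur, such as methyl or a phenyl bearing a carboxylic acid or an amine, would shift the number beyond the scatter. They also leave open whether the same change stays flat on a core with a longer linking chain.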